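The compounds below may be only part of what the source reports. "The series", "measured", "known", "first", "only" and "open" are said of these compounds alone.

Measured in an ADME assay on microsomes from liver (Rattus norvegicus) for metabolic stability, read by LC-MS, with a stated time of 10 min, tested at 0.5 uM; a higher number here means that more of the compound is left, a lower number that less of the compound is left:

- compound 1 `c1ccc2c(c1)CN[C@H](CN(CCCN1CCNCC1)[C@H]1CCCc3cccnc31)C2`: 88%
- compound 2 `c1ccc2c(c1)CN[C@@H](CN(CCCN1CCNCC1)[C@H]1CCCc3cccnc31)C2`: 100%
- compound 3 `c1cnc2c(c1)CCC[C@@H]2N(CCCN1CCNCC1)Cc1cc2ccccc2cn1`: 59%

Compound 3 stands lowest of these three, and its gaps to the other two lie beyond the scatter. Compound 4 `c1cnc2c(c1)CCC[C@@H]2N(CCCN1CCNCC1)Cc1nc2ccccc2[nH]1` has not been measured yet. Its change from compound 3 is 1H-benzimidazol-2-yl in place of isoquinolin-3-yl, on a saturated chain carbon bound to an amine nitrogen: 1H-benzimidazol-2-yl in place of isoquinolin-3-yl on a saturated chain carbon bound to an amine nitrogen.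

For the measured compounds named here, two measured steps concern that same place: a number 29 percentage points lower from compound 1 to compound 3 (beyond the scatter) and a number 41 percentage points lower from compound 2 to compound 3 (beyond the scatter). In both, isoquinolin-3-yl enters in place of 1,2,3,4-tetrahydroisoquinolin-3-yl. They show that a change here can move the number a long way, but neither involves 1H-benzimidazol-2-yl, so they give no direction for this swap. The third step, a number 12 percentage points higher from compound 1 to compound 2 (beyond the scatter), comes down to the fact that compounds 1 and 2 differ only in the configuration as drawn, and so it says little about the new group.

With compound 3 at 59% as the starting point, no clear shift is expected in this assay, though the uncertainty is wide. The expected change is a number 3 percentage points higher from compound 3 to compound 4 (within the scatter). For compound 4 the estimate is 62%, with an expected range from 38% to 85%.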

Compound 4, percent of the compound remaining: 29%
The estimate for compound 4 lay 33 percentage points above the measured number; measured number outside the range, below it.
By their numbers in this assay, from the lowest: compound 4; then compound 3; then compound 1; then compound 2.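

In this assay, the place on the saturated chain carbon bound to an amine nitrogen now has a measured direction for 1H-benzimidazol-2-yl, which gives a number 30 percentage points lower from compound 3 to compound 4 (beyond the scatter). For the compounds shown here, this shows that replacing one fused aromatic group with another is not a neutral exchange here, whereas the earlier steps at this place covered only isoquinolin-3-yl in place of 1,2,3,4-tetrahydroisoquinolin-3-yl. Compared directly with that partly saturated group, the new group gives steps larger than those seen for isoquinolin-3-yl, with a number 71 percentage points lower from compound 2 to compound 4 (beyond the scatter) and a number 59 percentage points lower from compound 1 to compound 4 (beyond the scatter), so compound 4 sets the lowest point so far among these four compounds.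

The swap brings in a hydrogen-bond donor and a five-membered aromatic ring together, and nothing shown here accounts for the lower number or says which of these changes matters. A close partner such as 1-methyl-1H-benzimidazol-2-yl, with a methyl group on the ring nitrogen in place of its hydrogen, would pull these two changes apart, and it stands outside the compounds shown.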